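This account rests on a few compounds, and the source may have more. Where it says the series, first, only, none or still open, it means among the compounds named here.

Compound 1 (`COc1ccc(C(=O)/C=C/c2cccc(F)c2)c2c1C=CC(C)(C)O2`) reads > 10000 nM in a functional assay on SW-620 cells (Homo sapiens) for antiproliferative activity, read by MTT assay, with a stated time of 24 h (a higher number here means a weaker inhibitor, a lower number a stronger inhibitor), and this is a limit of the assay, not a number. Going by the values given here, compound 2 (`COc1ccc(C(=O)/C=C/c2ccc([N+](=O)[O-])cc2)c2c1C=CC(C)(C)O2`) gives 3520 nM, the only true number so far. Among the compounds with values here, the one measured step, an at least 2.8-fold lower number from compound 1 to compound 2 (0.45 log units; beyond the scatter), falls at the same place as the next change. Its size is a lower bound, set by the limit of > 10000 nM in this assay, at which 1 of the 2 values shown sits.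

Compound 3 (`COc1ccc(/C=C/C(=O)c2ccc(OC)c3c2OC(C)(C)C=C3)cn1`) follows from compound 2: 6-methoxypyridin-3-yl in place of 4-nitrophenyl on a double-bonded chain carbon bound to a double-bonded chain carbon. Within the data shown here, compound 3 gives up the 4-nitrophenyl group, and the one step at this place, an at least 2.8-fold lower number from compound 1 to compound 2 (0.45 log units; beyond the scatter), favoured that group over 3-fluorophenyl. Among the measured compounds shown here, a modest step toward a higher number in this assay is therefore expected, no larger than that step. The expected change is a 2.3-fold higher number from compound 2 to compound 3 (0.36 log units; beyond the scatter). For compound 3 the estimated value is 8000 nM, with an expected range of 2500 nM to 25000 nM.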

Compound 3, half-maximal inhibitory concentration: > 10000 nM
Compound 3 gave a limit, no number (the forecaster's own chance of this, stated with the estimate: 40%); at least 1.2-fold (0.09 log units) between middle value and limit.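

In this assay compound 3 gives > 10000 nM, which is a limit of the assay and not a number. Leaving 4-nitrophenyl for 6-methoxypyridin-3-yl gives an at least 2.8-fold higher number from compound 2 to compound 3 (0.45 log units; beyond the scatter), a second group at this place that ends at the limit, so that of the three groups shown only 4-nitrophenyl gives a true number. The step between the other two groups, 3-fluorophenyl and 6-methoxypyridin-3-yl, cannot be read: the limit of > 10000 nM in this assay, at which 2 of the 3 values shown sit.

As far as these compounds go, how these two groups rank against each other therefore stays open, as does the true size of both steps away from 4-nitrophenyl. Also open, from the compounds shown here alone, is whether another group on this double-bonded chain carbon, such as 4-aminophenyl or 4-carboxyphenyl, would give a true number, and how it would compare with 4-nitrophenyl.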